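Removing the fluoro group from compound 2

A few compounds are considered here, and "the series" means these few. Any claim that something is new, unique, unknown or untested is made for them only; others in the source may bear on it.

Within the data shown here, the values measured so far come from an in vitro ADME assay on microsomes from liver (Homo sapiens) for metabolic stability (a higher number here means that the compound lasts longer, a lower number that the compound disappears faster), and read as follows.

Compound 1 `O=[N+]([O-])c1ccc(C2=NOC(c3ccc(N4CCCCC4)cc3)C2)o1` gives 0.47 h as its half-life
Compound 2 `O=C1COCCN1c1ccc(C2CC(c3ccc([N+](=O)[O-])o3)=NO2)cc1F` gives 8.31 h as its half-life

In this assay compound 2 stands highest of the two at 8.31 h as its half-life, and compound 1 lies well under it, a gap beyond the usual scatter. Compound 3 `O=C1COCCN1c1ccc(C2CC(c3ccc([N+](=O)[O-])o3)=NO2)cc1` has not yet been measured. It arises from compound 2 by a single change hydrogen in place of fluoro on an aromatic carbon with hydrogen in place of fluoro on an aromatic carbon, ortho to a 3-oxomorpholin-4-yl group. The two measured compounds differ in more than one place, so neither their values nor the gap between them speaks to this change alone. The expectation therefore rests only on how small the change is, with the rest of compound 2 left as it stands. Expected in this assay is a 1.3-fold lower number from compound 2 to compound 3 (0.11 log units; within the scatter) and so no step beyond the scatter, with a slight lean downward. For compound 3 the estimated half-life is 6.5 h with an expected range from 2.5 h to 14 h in this measurement.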

Compound 3, half-life: 10 h
For compound 3 the middle estimate is 1.5-fold (0.19 log units) below the measured one; low and high end bracket the measured number.
By their numbers in this assay, from the lowest: compound 1; then compounds 2 and 3 (each within the scatter of the next).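

In this assay, hydrogen in place of fluoro on the aromatic carbon ortho to a 3-oxomorpholin-4-yl group gives a 1.2-fold higher number from compound 2 to compound 3 (0.08 log units; within the scatter), so at this position the half-life does not depend on the fluoro group, at least with the 3-oxomorpholin-4-yl group in place. Compound 3 also makes it possible to read the other end of the molecule on its own: 3-oxomorpholin-4-yl in place of piperidin-1-yl on the aromatic carbon gives a 21-fold higher number from compound 1 to compound 3 (1.33 log units; beyond the scatter), and the wide gap that could not be assigned while only compounds 1 and 2 stood side by side now goes with this single exchange. Nothing at hand bears on why either step has the size it has.

Going by these compounds, only fluoro and hydrogen have been seen on this aromatic carbon, so it remains open whether chloro, methoxy or a nitrile there would leave the half-life in the same range, or whether fluoro would matter alongside piperidin-1-yl. On these data alone, it also remains open where other rings in place of 3-oxomorpholin-4-yl, such as morpholin-4-yl without the carbonyl or a piperazine, would fall between compound 1 and compound 3.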